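This account rests on a few compounds, and the source may have more. Where it says the series, first, only, none or still open, it means among the compounds named here.

Measured so far in a functional assay on the whole organism (strain albino) with Rattus norvegicus as the target, read by paw edema, with stated times of 1 h and 4 h, at a dose of 50 mg/kg by the oral route; a lower number here means a weaker effect, a higher number a stronger effect of the compound at the dose given:
Compound 1 `COc1ccc(C2CC(c3ccc(NC(=O)c4cc(Cl)ccc4OC)cc3)=NN2C)cc1` gives 93.2%.
Compound 2 `COc1ccc(Cl)cc1C(=O)Nc1ccc(C2=NN(C)C(c3ccc([N+](=O)[O-])cc3)C2)cc1` gives 97.4%.

Compound 1 stands lowest of these two numbers, but the step of a number 4.2 percentage points higher from compound 1 to compound 2 (within the scatter) lies within the scatter, so the two compounds cannot be ranked against each other. Compound 3 `COc1ccc(C2CC(c3ccc(NC(=O)c4cc(Cl)ccc4OC)cc3)=NN2c2ccccc2)cc1` has not yet been measured in this assay. It differs from compound 1 by phenyl in place of methyl on an amine nitrogen in a ring. Among the compounds with values here, no measured step touches this position: the only step available, a number 4.2 percentage points higher from compound 1 to compound 2 (within the scatter), concerns a substituent on an aromatic carbon elsewhere in the molecule and says nothing about the amine nitrogen in the ring. The expectation for compound 3 therefore rests only on the closeness of the two measured values, both high. Compound 3 is expected to give 88%, with a range from 70% to 98%. That estimate means a step of a number 5.2 percentage points lower from compound 1 to compound 3 (within the scatter), expected to remain within the scatter.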

Compound 3, a percentage reported as activity, at one dose (the size of the read-out at that dose, not a potency): 98%
For compound 3 the middle estimate is 10 percentage points below the measured one; the range from low to high includes it.
By their numbers in this assay, from the lowest: compounds 1, 2 and 3 (each within the scatter of the next).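

The amine nitrogen in the ring, which the earlier comparison did not touch, now has a step of its own: in this assay, phenyl in place of methyl gives a number 4.8 percentage points higher from compound 1 to compound 3 (within the scatter). At this dose, the much larger phenyl, with its six-membered aromatic ring of carbon only, therefore leaves the read-out within the scatter of the methyl compound. No evidence is available that would explain this result.

The compounds shown leave open how this nitrogen would respond to a group carrying other atoms, such as acetyl or a carboxylic acid, or to a longer chain such as n-butyl. They also leave open what the read-out would be if phenyl on this nitrogen were combined with nitro in place of methoxy on the aromatic carbon.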